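This account rests on a few compounds, and the source may have more. Where it says the series, first, only, none or still open, it means among the compounds named here.

In a functional assay on the whole organism with Mus musculus as the target (a lower number here means that less compound is needed, a higher number that more compound is needed for the effect), three compounds on a shared core differ in one group. Compound 1 (`OC1CCN(c2ccc(-c3ccccc3F)nn2)CC1`), with fluoro, gives 30 mg/kg. Compound 2 (`O=[N+]([O-])c1ccccc1-c1ccc(N2CCC(O)CC2)nn1`), with nitro, gives 81 mg/kg. Compound 3 (`Cc1ccccc1-c1ccc(N2CCC(O)CC2)nn1`), with methyl, gives 40 mg/kg. The measured 1.3-fold higher number from compound 1 to compound 3 (0.12 log units; within the scatter) lies within the usual scatter, while a 2.0-fold lower number from compound 2 to compound 3 (0.31 log units; beyond the scatter) lies just beyond it, so compound 3 stands level with compound 1 and apart from compound 2.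

Compound 4 (`Cc1cc(Cl)ccc1-c1ccc(N2CCC(O)CC2)nn1`) keeps the methyl group of compound 3 and gains one atom: chloro in place of hydrogen on an aromatic carbon. The new chloro sits on an aromatic carbon, meta to a methyl group and para to a large group. Among the measured compounds shown here, no measured step adds a chloro, so the evidence is only indirect. The widest exchange among the known groups, a 2.7-fold higher number from compound 1 to compound 2 (0.43 log units; beyond the scatter), is still modest, which suggests a small effect here too, and the data give no firm direction. The expected 1.1-fold lower number from compound 3 to compound 4 (0.06 log units; within the scatter) therefore stays within the scatter. For compound 4 the estimated value is 35 mg/kg, with an expected range from 15 mg/kg to 80 mg/kg.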

Compound 4, dose for half-maximal effect: 10 mg/kg
Compound 4: the middle estimate sits 3.5-fold (0.54 log units) above what was measured, and the stated range ends above it.
By their numbers in this assay, from the lowest: compound 4; then compounds 1 and 3 (each within the scatter of the next); then compound 2.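

Adding a single chloro to compound 3, on the aromatic carbon para to a large group and meta to a methyl group, gives a 4.0-fold lower number from compound 3 to compound 4 (0.60 log units; beyond the scatter) in this assay. Among the compounds shown here, this carbon had not been varied in the earlier compounds, and the step shows that one added heavy atom here can change how much compound is needed by more than the usual scatter. No measurement available here explains why the chloro has this effect.

As far as these compounds go, it remains open whether this gain is particular to chloro or would also appear with another group at this carbon, such as a methoxy or an amine. It is also unknown whether the chloro would give a similar step with fluoro or nitro in place of the methyl group.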